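The source may report more compounds than this note shows. Statements on the series, on what has been measured and on what is new or still open speak of the compounds shown alone.

Measured so far:
Compound 1 `CCCc1nc(-c2ccccc2)c(CNCCCN2CCN(c3ccc(F)cc3)CC2)o1` gives 62.5% in an assay on HEK293 cells for inhibition of Voltage-dependent T-type calcium channel subunit alpha-1G (Homo sapiens), read by fluorescence, tested at 10 uM; on this read-out higher numbers stand for more inhibition at the one concentration tested (going by the name of the read-out) and lower numbers for less inhibition.
Compound 2 `CCCc1nc(-c2ccccc2)c(CNCCCN2CCN(c3ccccc3)CC2)o1` gives 43.7% in this assay.

Among the measured compounds shown here, compound 2 stands lowest of the two numbers in this assay; its only neighbour is compound 1, and the single measured step between them, a number 18.8 percentage points lower from compound 1 to compound 2 (beyond the scatter), is hydrogen in place of fluoro on an aromatic carbon. This is the whole of the measured evidence, and it bears on compound 3 only loosely: it shows that one substituent on the six-membered aromatic ring of carbon only can move the read-out beyond the scatter, but it says nothing about the direction a methoxy would take.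

Compound 3 `CCCc1nc(-c2ccccc2)c(CNCCCN2CCN(c3ccccc3OC)CC2)o1` differs from compound 2 by methoxy in place of hydrogen on an aromatic carbon. For the measured compounds named here, no measured pair swaps hydrogen for methoxy, so the direction of the step cannot be read from the data; a step of the size seen for fluoro is possible either way, and a step within the scatter is equally plausible. On that basis compound 3 is estimated at 50%, with a range of 28% to 72%. The estimated step from compound 2 is a number 6.3 percentage points higher from compound 2 to compound 3 (within the scatter), expected to stay within the scatter.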

Compound 3, a percentage reported as inhibition, at one concentration (the size of the read-out at that concentration, not a potency): 41%
Beside the measured number, compound 3's estimate is 9 percentage points above it, and the stated range covers the measured number.
By their numbers in this assay, from the lowest: compounds 3 and 2 (each within the scatter of the next); then compound 1.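

In this assay, methoxy on an aromatic carbon ortho to a large group gives a number 2.7 percentage points lower from compound 2 to compound 3 (within the scatter), so 2-methoxyphenyl and phenyl cannot be told apart on this read-out. The comparison with the 4-fluorophenyl compound gives a number 21.5 percentage points lower from compound 1 to compound 3 (beyond the scatter), and with the earlier step of a number 18.8 percentage points lower from compound 1 to compound 2 (beyond the scatter) this leaves compound 1 as the only one of the three set apart beyond the scatter, with compound 2 and compound 3 together as a group. Nothing measured here gives a reason for either the step that stays within the scatter or the one that goes beyond it.

The step from 4-fluorophenyl to 2-methoxyphenyl changes both the group and its place on the ring, so the compounds shown do not separate the two: fluoro ortho to a large group and methoxy in the place fluoro holds in compound 1 both remain open. From the compounds shown here alone, it is also open whether chloro, trifluoromethyl or hydroxy on this ring would stand with compound 1 or with compound 2 and compound 3, and whether any of these steps would hold with a longer chain in place of the propyl group on the shared core.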